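The compounds below may be only part of what the source reports. "The series", "measured", "known", "first", "only" and "open" are said of these compounds alone.

Measured compounds:
compound 1, `O=c1cc(-c2ccccc2)oc2cc(OCCCN3CCN(c4ccccc4)CC3)ccc12`: 6.65 nM
compound 2, `O=c1cc(-c2ccc(Cl)cc2)oc2cc(OCCCN3CCN(c4ccccc4)CC3)ccc12`: 8.47 nM
compound 3, `O=c1cc(-c2ccccc2)oc2cc(OCCBr)ccc12`: 127 nM

Notes on the series. All three numbers come from a functional assay for antagonist activity at Adrenergic receptor alpha-1 (Rattus norvegicus); a higher number here means weaker binding, a lower number tighter binding. Compound 1 and compound 2 share one core and differ only by chloro in place of hydrogen on an aromatic carbon. The step this change made is a 1.3-fold higher number from compound 1 to compound 2 (0.11 log units; within the scatter), so the two compounds cannot be told apart on this assay.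

Compound 3 carries a different core; the difference between the core of compound 1 and the core of compound 3 is not broken down here. On this assay compound 3 stands highest of the three, with the nearest number that of compound 2 and the furthest that of compound 1, both gaps beyond the scatter.

Compound 4, `O=c1cc(-c2ccc(Cl)cc2)oc2cc(OCCBr)ccc12`, is not yet measured. Among the compounds with values here, it differs from compound 3 by chloro in place of hydrogen on an aromatic carbon, which is the same change as the one from compound 1 to compound 2, on the same kind of place in a phenyl ring becoming 4-chlorophenyl. Within the data shown here, the only guide to its effect is the earlier pair, where it left the number essentially unchanged; the step expected here is therefore a 1.2-fold higher number from compound 3 to compound 4 (0.07 log units; within the scatter), the expectation resting on compound 1 and compound 2 showing a 1.3-fold higher number from compound 1 to compound 2 (0.11 log units; within the scatter). On that basis compound 4 is estimated at 150 nM, with a likely range from 70 nM to 320 nM, close to compound 3 with its 127 nM.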

Compound 4, dissociation constant: 119 nM
Estimate against measurement, compound 4: 1.3-fold (0.10 log units) above; the range from low to high includes it.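

In this assay, phenyl to 4-chlorophenyl gives a 1.1-fold lower number from compound 3 to compound 4 (0.03 log units; within the scatter), so on this second core the change again leaves the number essentially where it stood, and the two steps do not differ: the same change on two cores in this assay, a 1.3-fold higher number (0.11 log units; within the scatter) from compound 1 to compound 2 and a 1.1-fold lower number (0.03 log units; within the scatter) from compound 3 to compound 4, 1.4-fold (0.13 log units) apart, within the scatter of two such steps

Within these two pairs, the change therefore carries from one core to the other in the plain sense that neither core shows a step that can be read, even though the two cores sit at clearly different levels in this assay. This is agreement between two steps lying within the scatter, so it shows only that chloro in place of hydrogen at this place makes no measurable difference on either core; it does not show that a step of real size would carry across, and two pairs set no rule for any further core.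

The compounds shown leave open whether a different group at the same place on the phenyl ring, such as methoxy, trifluoromethyl, an amine or a carboxylic acid, would give a step beyond the scatter. They also leave open whether any such step would keep its size and direction on going from one of these cores to the other.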